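From 3-fluorophenyl to 5-fluoropyridin-3-yl in compound 1

The compounds below may be only part of what the source reports. "The series", "measured", "known", "first", "only" and "open" are said of these compounds alone.

In a functional assay on HepG2 cells (Homo sapiens) for cytotoxicity, read by MTT assay, with a stated time of 72 h (on this read-out higher numbers stand for weaker inhibition and lower numbers for stronger inhibition), compound 1 (`Nc1ccccc1NC(=O)c1ccc(NC(=S)NCc2cccc(F)c2)cc1`) gives 2900 nM. That value lies within the scatter of compound 2 (`Nc1ccccc1NC(=O)c1ccc(CNC(=O)c2cc3cnccc3[nH]2)cc1`) at 1700 nM. Compound 3 (`Nc1ccccc1NC(=O)c1ccc(Cn2cc(-c3ccc(NC(=O)NCc4cccnc4)cc3)nn2)cc1`) gives 8100 nM, a higher number than that of compound 1 and beyond the scatter.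

Compound 4 (`Nc1ccccc1NC(=O)c1ccc(NC(=S)NCc2cncc(F)c2)cc1`) has 5-fluoropyridin-3-yl in place of 3-fluorophenyl on a saturated chain carbon bound to an amide-type nitrogen. Going by the values given here, no measured pair shows a change of this kind, so the expectation rests on little. The estimate is a small move toward a higher number in this assay, not beyond the scatter: a 1.3-fold higher number from compound 1 to compound 4 (0.12 log units; within the scatter). Compound 4 is expected at 3800 nM, with an estimated range of 1600 nM to 9000 nM.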

Compound 4, half-maximal inhibitory concentration: 13000 nM
Beside the measured number, compound 4's estimate is 3.4-fold (0.53 log units) below it; the whole stated range lies below it.
By their numbers in this assay, from the lowest: compounds 2 and 1 (each within the scatter of the next); then compounds 3 and 4 (each within the scatter of the next).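

In this assay, going by these compounds alone, the change from 3-fluorophenyl to 5-fluoropyridin-3-yl on a saturated chain carbon bound to an amide-type nitrogen gives a 4.5-fold higher number from compound 1 to compound 4 (0.65 log units; beyond the scatter) and provides the first single-place pair. This place therefore responds to a ring nitrogen entering with the fluorine retained and the heavy-atom count unchanged. No measurement shown explains the step.

On these data alone, whether the ring nitrogen acts the same way without fluorine remains open. The compounds shown also leave open how this place responds to plain phenyl, pyridin-3-yl or a saturated amine such as piperidine.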